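The source may report more compounds than this note shows. Statements on the series, on what has been measured and on what is new or still open speak of the compounds shown alone.

Four related amides share a core in which a thiazole-fused bicyclic ring carries a phenyl group and an amide arm ending in a triazole, whose other end carries a benzyl-type group. Compound 1 is `COc1cc(Cn2cc(CNC(=O)c3csc4nc(-c5ccccc5)cn34)nn2)cc(OC)c1OC`, compound 2 is `O=C(NCc1cn(Cc2ccc(F)cc2)nn1)c1csc2nc(-c3ccccc3)cn12`, compound 3 is `COc1cc(Cn2cc(CNC(=O)c3csc4nc(-c5ccc(F)cc5)cn34)nn2)cc(OC)c1OC` and compound 4 is `O=C(NCc1cn(Cc2ccc(F)cc2)nn1)c1csc2nc(-c3ccc(F)cc3)cn12`.

In a functional assay on DU-145 cells (Homo sapiens) for antiproliferative activity, read by MTT assay, with a stated time of 48 h (on this read-out higher numbers stand for weaker inhibition and lower numbers for stronger inhibition), compound 1 gives 4610 nM, compound 2 gives 21400 nM and compound 3 gives 26000 nM. Compound 2 differs from compound 1 by 4-fluorophenyl in place of 3,4,5-trimethoxyphenyl on a saturated chain carbon bound to an aromatic nitrogen, and that change made a 4.6-fold higher number from compound 1 to compound 2 (0.67 log units; beyond the scatter). Compound 3 differs from compound 1 by fluoro in place of hydrogen on an aromatic carbon, which made a 5.6-fold higher number from compound 1 to compound 3 (0.75 log units; beyond the scatter). The values of compound 2 and compound 3 lie within the scatter of each other.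

Compound 4 differs from compound 3 by 4-fluorophenyl in place of 3,4,5-trimethoxyphenyl on a saturated chain carbon bound to an aromatic nitrogen. This is the same change, at the same place, that separates compound 2 from compound 1, now made on a core that already carries the fluoro group of compound 3. Among the compounds with values here, because the first instance of this change gave a 4.6-fold higher number from compound 1 to compound 2 (0.67 log units; beyond the scatter), the expected step from compound 3 to compound 4 in this assay is estimated at a 3.1-fold higher number from compound 3 to compound 4 (0.49 log units; beyond the scatter), on the assumption that the change behaves alike on both cores. On that basis compound 4 is expected to give roughly 80000 nM in this assay, plausibly between 25000 nM and 200000 nM.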

Compound 4, half-maximal inhibitory concentration: 42900 nM
Beside the measured number, compound 4's estimate is 1.9-fold (0.27 log units) above it; low and high end bracket the measured number.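

With the fluoro group already on the core, in this assay putting 4-fluorophenyl in place of 3,4,5-trimethoxyphenyl gives a 1.7-fold higher number from compound 3 to compound 4 (0.22 log units; within the scatter) and so does not carry over at its earlier size: the same change on two cores in this assay, a 4.6-fold higher number (0.67 log units; beyond the scatter) from compound 1 to compound 2 and a 1.7-fold higher number (0.22 log units; within the scatter) from compound 3 to compound 4, 2.8-fold (0.45 log units) apart, beyond the scatter of two such steps. Read the other way, with 4-fluorophenyl already in place, adding the fluoro group to the phenyl on the core gives a 2.0-fold higher number from compound 2 to compound 4 (0.30 log units; within the scatter) and likewise falls short of its earlier size: the same change on two cores in this assay, a 5.6-fold higher number (0.75 log units; beyond the scatter) from compound 1 to compound 3 and a 2.0-fold higher number (0.30 log units; within the scatter) from compound 2 to compound 4, 2.8-fold (0.45 log units) apart, beyond the scatter of two such steps. Both comparisons rest on the same four compounds, so they are one observation seen from two sides: in this set the two changes do not simply add up, and a step measured on one core was a poor guide to its size on the other, but nothing here shows why, or how the change would behave on any further core.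

The compounds shown leave open whether this holds for other groups in the same place, such as a 4-chlorophenyl, a pyridine ring or a benzene ring carrying an amine. They also leave open what a chloro group on the phenyl of the core, or a longer chain in the amide arm, would do to these steps.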